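A few compounds are considered here, and "the series" means these few. Any claim that something is new, unique, unknown or untested is made for them only; others in the source may bear on it.

Measured compounds:

Compound 1, `c1ccc(C(C2Cc3ccccc3O2)n2cncn2)cc1`, gives 85.7%.
Compound 2, `O=[N+]([O-])c1ccc2c(c1)CC(C(c1ccccc1)n1cncn1)O2`, gives 58.4%.
Compound 3, `Fc1ccc(C(C2Cc3ccccc3O2)n2cncn2)cc1`, gives 98.8%.

These three share one core and differ only in a substituent on an aromatic carbon. In an assay for inhibition of Aromatase (Homo sapiens), tested at 20 uM (a higher number here means more inhibition at the concentration tested (going by the name of the read-out), a lower number less inhibition), compound 3 stands highest of the three: compound 1 lies nearest, and the step of a number 13.1 percentage points higher from compound 1 to compound 3 (beyond the scatter) is beyond the scatter, while compound 2 lies furthest, since the step of a number 27.3 percentage points lower from compound 1 to compound 2 (beyond the scatter) went the other way.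

Compound 4, `Cc1ccc(C(C2Cc3ccccc3O2)n2cncn2)cc1`, has not yet been measured in this assay. It differs from compound 3 by methyl in place of fluoro on an aromatic carbon. Among the measured compounds shown here, no measured step swaps one substituent directly for another at this carbon; the two that bear on the question each start from an unsubstituted carbon in compound 1. Fluoro gave a modest rise, nitro a modest fall. Methyl is a third substituent with no measured precedent here, so the direction of its effect is uncertain. Because compound 1, with hydrogen, gave 85.7%, and compound 3 already sits high in this assay with 98.8%, the expected step of a number 10.8 percentage points lower from compound 3 to compound 4 (beyond the scatter) is a small drop, possibly within the scatter. Compound 4 is estimated to give 88%, with a range from 70% to 99%.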

Compound 4, a percentage reported as inhibition, at one concentration (the size of the read-out at that concentration, not a potency): 96.8%
Compound 4: the middle estimate sits 8.8 percentage points below what was measured; the range from low to high includes it.
By their numbers in this assay, from the lowest: compound 2; then compound 1; then compounds 4 and 3 (each within the scatter of the next).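

In this assay the step of a number 2 percentage points lower from compound 3 to compound 4 (within the scatter) shows that, on this aromatic carbon para to a large group, fluoro and methyl cannot be told apart. The step of a number 11.1 percentage points higher from compound 1 to compound 4 (beyond the scatter) adds a second substituent at this carbon that reads above hydrogen, so the rise is no longer seen with fluoro alone, and two quite different atoms in this place, fluorine and carbon, give matching results. Nothing measured here explains why these two groups read alike.

On these data alone, whether larger groups are also accepted at this carbon remains open, for instance an ethyl or longer chain, a methoxy, an amine or a carboxylic acid. A reading at one concentration is also not a potency, so compound 3 and compound 4 could still differ in a full concentration series.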